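Working notes: 3-chlorophenyl for 2-fluorophenyl, compound 3

This account rests on a few compounds, and the source may have more. Where it says the series, first, only, none or still open, it means among the compounds named here.

Two members of the series have been measured in an ADME assay on HEp-2 cells (Homo sapiens) for cytotoxicity, read by trypan blue exclusion, with a stated time of 24 h; a higher number here means that more compound is tolerated, a lower number that less compound is tolerated. Compound 1 `C/C(=N\N=C1/SCC(=O)N1Cc1cccc(Cl)c1)c1ccccn1` gives 21 ug/mL. Compound 2 `C/C(=N\N=C1/SCC(=O)N1Cc1ccccc1F)c1cccs1` gives 15 ug/mL, the lowest of the two numbers, and its nearest neighbour is compound 1, whose value lies within the scatter of it. Compound 1 and compound 2 differ in more than one place, so their two values show only that both sit at a similar level; no single step can be read from them.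

Compound 3 `C/C(=N\N=C1/SCC(=O)N1Cc1cccc(Cl)c1)c1cccs1` has not yet been measured in this assay. It differs from compound 2 in one place: 3-chlorophenyl in place of 2-fluorophenyl on a saturated chain carbon bound to an amide-type nitrogen in a ring. Compound 1 carries the same 3-chlorophenyl on the same position and gives a value within the scatter of compound 2, so no step beyond the scatter is expected here; the step of a 1.2-fold higher number from compound 2 to compound 3 (0.08 log units; within the scatter) is expected to be small, if anything upward. Compound 3 is expected at 18 ug/mL, with a range of 9 ug/mL to 36 ug/mL.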

Compound 3, half-maximal cytotoxic concentration in the HEp-2 assay: 21 ug/mL
Estimate against measurement, compound 3: 1.2-fold (0.07 log units) below; low and high end bracket the measured number.
By their numbers in the HEp-2 assay, from the lowest: compounds 2, 1 and 3 (each within the scatter of the next).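

Going by these compounds alone, in the HEp-2 assay, the first single-place steps are a 1.4-fold higher number from compound 2 to compound 3 (0.15 log units; within the scatter) for 3-chlorophenyl in place of 2-fluorophenyl on a saturated chain carbon bound to an amide-type nitrogen in a ring, and no change at the digits printed from compound 1 to compound 3 (within the scatter) for thiophen-2-yl in place of pyridin-2-yl on a carbon with a double bond to nitrogen, both within the scatter. In a physicochemical assay, with a stated time of 30 min (a higher number here means a weaker inhibitor, a lower number a stronger inhibitor), compound 2 gives > 5000000 nM, which is a limit of the assay and not a number. In the physicochemical assay compound 3 gives > 5000000 nM, again a limit of the assay.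

The step between these two compounds in the physicochemical assay cannot be read, and both values stand at the same limit: the limit of > 5000000 nM in the physicochemical assay, at which 2 of the 2 values shown sit.

On these data alone, whether an amine or a carboxylic acid in place of the substituted phenyl on this saturated chain carbon would move the number in the HEp-2 assay beyond the scatter remains open.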